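Chloro to carboxy on the tetrazole aryl group: stability notes

The source may report more compounds than this note shows. Statements on the series, on what has been measured and on what is new or still open speak of the compounds shown alone.

Compound 1 `CCCCCCCCc1ccc(OCC(=O)Cn2nnc(-c3cccc(Cl)c3)n2)cc1` gives 69% in an ADME assay on S9 fraction from liver (Rattus norvegicus) for metabolic stability, read by LC-MS, using NADPH, with a stated time of 30 min (on this read-out lower numbers stand for a less stable compound and higher numbers for a more stable compound), the higher of the two numbers obtained so far; nearest stands compound 3 `CCCCCCCCc1ccc(OCC(=O)Cn2nnc(-c3cccnc3)n2)cc1`, which gives 12%. Compound 2 `CCCCCCCCc1ccc(OCC(=O)Cn2nnc(-c3ccncc3)n2)cc1` returns only a limit of this assay, < 5%, (the limit of < 5% in this assay, at which 1 of the 3 values shown sits). The measured steps are a number at least 64 percentage points lower from compound 1 to compound 2 (beyond the scatter) and a number 57 percentage points lower from compound 1 to compound 3 (beyond the scatter), both large, and a number at least 7 percentage points higher from compound 2 to compound 3 (that floor lies within the scatter). Compound 4 `CCCCCCCCc1ccc(OCC(=O)Cn2nnc(-c3cccc(C(=O)O)c3)n2)cc1` differs from compound 1 by carboxy in place of chloro on an aromatic carbon. Among the measured compounds shown here, no measured step alters a substituent on the six-membered aromatic ring of carbon only; both large drops come from exchanging that ring for a pyridyl, so they give no direct guide here. The expected step is a number 1 percentage points higher from compound 1 to compound 4 (within the scatter), none beyond the scatter. Compound 4 is estimated at 70%, between 35% and 95%.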

Compound 4, percent of the compound remaining: < 5%
Compound 4: no number, only a limit; the forecaster's own chance of this, stated with the estimate: 5%; at least 65 percentage points between middle value and limit.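

Carboxy in place of chloro on the six-membered aromatic ring of carbon only gives a large loss with that ring kept, which the pyridyl compounds could not show: a number at least 64 percentage points lower from compound 1 to compound 4 (beyond the scatter). Against the pyridin-3-yl compound, the reading is a number at least 7 percentage points lower from compound 3 to compound 4 (that floor lies within the scatter), and the step between the two compounds at the limit cannot be read. In this assay, compound 4 returns only a limit, < 5%: the limit of < 5% in this assay, at which 2 of the 4 values shown sit.

Open, as far as these compounds go, is whether the loss is specific to the carboxylic acid. A methyl ester, a primary amide or an amine at this place would test that.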